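From hydroxy to methoxy in an antiproliferative pair

This account rests on a few compounds, and the source may have more. Where it says the series, first, only, none or still open, it means among the compounds named here.

In a functional assay on M14 cells (Homo sapiens) for antiproliferative activity, read by sulforhodamine B assay, with a stated time of 48 h (on this read-out lower numbers stand for stronger inhibition and higher numbers for weaker inhibition), compound 1 `O=C(NCCCNc1cc(-c2cn(-c3ccccc3)nc2-c2cccc(O)c2)ccn1)Nc1ccc(F)cc1` gives 1570 nM. Compound 2 `O=C(NCCCNc1cc(-c2cn(-c3ccccc3)nc2-c2cccc(O)c2)ccn1)Nc1cccc(C(F)(F)F)c1`, which carries 3-(trifluoromethyl)phenyl in place of 4-fluorophenyl on an amide-type nitrogen, gives 2180 nM. These two numbers lie within the scatter of each other, so compound 1 cannot be ranked ahead of compound 2.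

Compound 3 `COc1cccc(-c2nn(-c3ccccc3)cc2-c2ccnc(NCCCNC(=O)Nc3ccc(F)cc3)c2)c1` has not yet been measured. It differs from compound 1 by one change, methyl in place of hydrogen on an oxygen on an aromatic ring, which turns 3-hydroxyphenyl into 3-methoxyphenyl. Going by the values given here, the only measured step, a 1.4-fold higher number from compound 1 to compound 2 (0.14 log units; within the scatter), concerns the amide-type nitrogen and leaves the hydroxy group untouched. Among the compounds with values here, no measured step therefore speaks directly to this change, and its direction remains uncertain. The estimated step is a 1.6-fold higher number from compound 1 to compound 3 (0.20 log units; within the scatter), a small expected move toward weaker inhibition that may well stay within the scatter. For compound 3 the expected value in this assay is 2500 nM, with an estimated range from 900 nM to 7500 nM.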

Compound 3, half-maximal inhibitory concentration: 6710 nM
Compound 3: the middle estimate sits 2.7-fold (0.43 log units) below what was measured; measured number inside the range.
By their numbers in this assay, from the lowest: compounds 1 and 2 (each within the scatter of the next); then compound 3.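

Replacing hydrogen with methyl on the oxygen of the 3-hydroxyphenyl group gives, in this assay, a 4.3-fold higher number from compound 1 to compound 3 (0.63 log units; beyond the scatter), so 3-methoxyphenyl reads toward weaker inhibition than 3-hydroxyphenyl on the core of compound 1. The earlier step, a 1.4-fold higher number from compound 1 to compound 2 (0.14 log units; within the scatter), concerned only the aryl group on the amide-type nitrogen and gave no separable difference, whereas this single change on the oxygen does move the number beyond the scatter, though modestly. Nothing measured here explains why the number rises.

On these data alone, whether the step comes from losing the hydrogen on the oxygen or from adding the methyl stays open, and an amine or an ethoxy group in place of the hydroxy group would help to tell these two readings apart. As far as these compounds go, it is also open whether the same change would give a step of similar size when the 3-(trifluoromethyl)phenyl group of compound 2 replaces the 4-fluorophenyl group of compound 1.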